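Piperazine in Place of Dimethylamino on a Diphenylamino Core

The compounds below may be only part of what the source reports. "The series", "measured", "known", "first", "only" and "open" are said of these compounds alone.

Compound 1, `CCN(CC)c1ccc(/C=C2/SC(Nc3ccccc3)=NC2=O)cc1`, gives 9900 nM in a functional assay on H460/TaxR cells (Homo sapiens) for cytotoxicity, read by sulforhodamine B assay, with a stated time of 48 h; a lower number here means that less compound is needed, a higher number that more compound is needed for the effect. Compound 2, `CN1CCN(c2ccc(/C=C3/SC(Nc4ccccc4)=NC3=O)cc2)CC1`, gives 2500 nM in this assay. Compound 3, `CN(C)c1ccc(/C=C2/SC(N(c3ccccc3)c3ccccc3)=NC2=O)cc1`, gives only a limit of the assay, > 100000 nM, in this assay.

Compound 3 thus stands at the upper limit, as shown by the limit of > 100000 nM in this assay, at which 1 of the 3 values shown sits, with no number of its own. Compound 4, `O=C1N=C(N(c2ccccc2)c2ccccc2)S/C1=C/c1ccc(N2CCNCC2)cc1`, differs from compound 3 in one place: piperazin-1-yl in place of dimethylamino on an aromatic carbon. Among the measured compounds shown here, the one measured step that bears on this change is a 4.0-fold lower number from compound 1 to compound 2 (0.60 log units; beyond the scatter), where a ring amine entered in place of a dialkylamino group on the same aromatic carbon; compound 2 there differs from compound 4 in carrying a methyl on the ring. On that basis a step in the same direction is expected, of a size near an at least 1.6-fold lower number from compound 3 to compound 4 (0.22 log units; that floor lies within the scatter), though compound 3 starts from a limit and the number for compound 4 may again be only a limit. The estimate for compound 4 is 60000 nM, with a range from 15000 nM to 250000 nM.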

Compound 4, half-maximal effective concentration: > 100000 nM
Compound 4: no number, only a limit; the forecaster's own chance of this, stated with the estimate: 55%; at least 1.6-fold (0.22 log units) between middle value and limit.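

Neither compound 3 nor compound 4 has a number of its own, so no step between them can be read: the limit of > 100000 nM in this assay, at which 2 of the 4 values shown sit.

The compounds shown leave open whether piperazin-1-yl in place of dimethylamino changes the result in this assay on the shared core of compound 3 and compound 4.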